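The source may report more compounds than this note shows. Statements on the series, on what has been measured and on what is new or still open speak of the compounds shown alone.

Among the measured compounds shown here, compound 1 `CN1CCN(C(=S)SCCCOc2ccc(C(=O)/C=C/c3ccc(Cl)cc3)cc2)CC1` is one of three compounds measured in a functional assay on MGC-803 cells (Homo sapiens) for inhibition, read by MTT assay, with a stated time of 72 h; a higher number here means a weaker inhibitor, a lower number a stronger inhibitor. Compound 1 gives 29400 nM, the highest of the three numbers, though neither companion is far off: compound 2 `COc1ccc(/C=C/C(=O)c2ccc(OCCCSC(=S)N3CCN(C)CC3)cc2)cc1` gives 19400 nM, and compound 3 `CN1CCN(C(=S)SCCCOc2ccc(C(=O)/C=C/c3cc(F)cc(F)c3)cc2)CC1` gives 16300 nM. The steps among them, a 1.5-fold lower number from compound 1 to compound 2 (0.18 log units; within the scatter), a 1.8-fold lower number from compound 1 to compound 3 (0.26 log units; within the scatter) and a 1.2-fold lower number from compound 2 to compound 3 (0.08 log units; within the scatter), all lie within the scatter, so the three are indistinguishable in this assay.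

Compound 4 `O=C(/C=C/c1ccc(Cl)cc1)c1ccc(OCCCSC(=S)N2CCCCC2)cc1` has not yet been measured. It differs from compound 1 at the other end of the molecule: piperidin-1-yl in place of 4-methylpiperazin-1-yl on a thiocarbonyl carbon. For the measured compounds named here, none of the measured steps touches this part of the shared core; each of them alters only the aromatic ring on the double-bonded chain, and each stayed within the scatter. There is therefore no measured evidence for any direction here, and the expectation is no step beyond the scatter in this assay.

Compound 4 is accordingly estimated at 29000 nM, with a likely range from 12000 nM to 70000 nM, which corresponds to an expected step of a 1.0-fold lower number from compound 1 to compound 4 (0.01 log units; within the scatter).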

Compound 4, half-maximal inhibitory concentration: 56800 nM
The estimate for compound 4 lay 2.0-fold (0.29 log units) below the measured number; low and high end bracket the measured number.
By their numbers in this assay, from the lowest: compounds 3, 2, 1 and 4 (each within the scatter of the next, the first and the last beyond it).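

In this assay, among the compounds shown here, there is a 1.9-fold higher number from compound 1 to compound 4 (0.29 log units; within the scatter) and this is the first measured change at the thiocarbonyl carbon, at the other end of the molecule from the aromatic ring changed in the earlier steps. Piperidin-1-yl in place of 4-methylpiperazin-1-yl swaps a ring with two nitrogens for a ring with one, yet compound 1 and compound 4 remain indistinguishable in this assay, as the earlier compounds were with one another. No measurement shown links this step to any property of either ring.

The compounds shown carry only these two rings on the thiocarbonyl carbon, so how far this position tolerates change remains open. A morpholin-4-yl ring, a diethylamino group or a piperazine bearing a longer chain in place of methyl could each test it further.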